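Amide variation on the shared core in paw edema

The source may hold more compounds than are shown below. What is called first, only, known or untested is meant among the compounds shown, and "the series" means these compounds.

Measured so far:
compound 1 `COc1cc2c(cc1OC)C(CC(=O)O)CC2` — 18.8%
compound 2 `CCNC(=O)CC1CCc2cc(OC)c(OC)cc21` — 15.6%
compound 3 `CCCCNC(=O)CC1CCc2cc(OC)c(OC)cc21` — 31.3%

All three numbers come from a functional assay on the whole organism (strain Wistar) for inhibition, with Rattus norvegicus as the target, read by paw edema, with stated times of 60 min and 1 h, at a dose of 100 mg/kg by the oral route; a higher number here means more inhibition at the dose given (going by the name of the read-out), a lower number less inhibition. Compound 3 stands highest of the three: the nearest is compound 1 (a number 12.5 percentage points higher from compound 1 to compound 3 (beyond the scatter)), the furthest compound 2 (a number 15.7 percentage points higher from compound 2 to compound 3 (beyond the scatter)). Between compound 1 and compound 2 the difference stays within the scatter (a number 3.2 percentage points lower from compound 1 to compound 2 (within the scatter)).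

Compound 4 `COc1cc2c(cc1OC)C(CC(=O)NC(C)(C)C)CC2` is the next member. It differs from compound 3 only in the group on the amide-type nitrogen: tert-butyl in place of butyl on an amide-type nitrogen. Among the compounds with values here, no measured step exchanges one group for another of the same atom count joined differently, so the only step that bears on this one at all is the growth of the group on that nitrogen from compound 2 to compound 3, a number 15.7 percentage points higher from compound 2 to compound 3 (beyond the scatter), a modest rise. That step says nothing about rearranging the carbons once the count is kept, and the acid compound 1 gives no further guidance. The expectation is therefore a step of no more than the scatter, leaning slightly down from compound 3: a number 5.3 percentage points lower from compound 3 to compound 4 (within the scatter). For compound 4 in this assay the estimate is 26%, with a range from 12% to 40%.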

Compound 4, a percentage reported as inhibition, in the whole organism at one dose (the size of the read-out at that dose, not a potency): 31.3%
Compound 4: the middle estimate sits 5.3 percentage points below what was measured; the range from low to high includes it.
By their numbers in this assay, from the lowest: compounds 2 and 1 (each within the scatter of the next); then compounds 3 and 4 (each within the scatter of the next).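

In this assay, rearranging the carbons of the group on the amide-type nitrogen leaves the read-out unmoved, with tert-butyl in place of butyl (no change at the digits printed from compound 3 to compound 4 (within the scatter)), so this pair shows no dependence on branching at a kept carbon count. The branched group also keeps the gain that butyl showed over the ethyl amide (a number 15.7 percentage points higher from compound 2 to compound 4 (beyond the scatter)) and over the acid (a number 12.5 percentage points higher from compound 1 to compound 4 (beyond the scatter)), so among the compounds shown that gain is not confined to the unbranched chain. No measurement at hand explains why the two groups read alike.

The compounds shown leave open whether a longer chain such as hexyl, or a ring such as cyclohexyl or phenyl on the same nitrogen, would extend the rise over the ethyl amide or level off, and whether a dimethylamide, which lacks the amide hydrogen, would keep it. From the compounds shown here alone, each figure is also a read-out at a single dose, so whether compound 3 and compound 4 would still read alike at other doses remains open.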